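Trifluoromethyl in Place of Chloro on Compound 1

This account rests on a few compounds, and the source may have more. Where it says the series, first, only, none or still open, it means among the compounds named here.

Among the measured compounds shown here, compound 1 `C=CCn1c(=O)/c(=C\c2ccccc2Cl)[nH]c(=O)/c1=C\c1ccccc1OC` gives the lowest of the two numbers known in a functional assay on MOLT-4 cells (Homo sapiens) for cytotoxicity, read by CCK-8 assay, with a stated time of 72 h (on this read-out lower numbers stand for stronger inhibition and higher numbers for weaker inhibition), at 4400 nM. Compound 2 `C=CCn1c(=O)/c(=C\c2cc(Br)ccc2F)[nH]c(=O)/c1=C\c1ccccc1OC`, which carries 5-bromo-2-fluorophenyl in place of 2-chlorophenyl, gives 12900 nM, a step of a 2.9-fold higher number from compound 1 to compound 2 (0.47 log units; beyond the scatter). Compound 3 `C=CCn1c(=O)/c(=C\c2ccccc2C(F)(F)F)[nH]c(=O)/c1=C\c1ccccc1OC` differs from compound 1 by trifluoromethyl in place of chloro on an aromatic carbon. For the measured compounds named here, the only measured step changes the same ring and weakened the number modestly, so a modest move in the same direction, or none beyond the scatter, is expected, estimated as a 1.5-fold higher number from compound 1 to compound 3 (0.17 log units; within the scatter). Compound 3 is therefore expected near 6500 nM, within 2500 nM to 16000 nM.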

Compound 3, half-maximal inhibitory concentration: 4400 nM
For compound 3 the middle estimate is 1.5-fold (0.17 log units) above the measured one; measured number inside the range.
By their numbers in this assay, from the lowest: compounds 1 and 3 (each within the scatter of the next); then compound 2.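

Trifluoromethyl in place of chloro, on an aromatic carbon ortho to a large group, gives no change at the digits printed from compound 1 to compound 3 (within the scatter) in this assay, so this position takes four heavy atoms in place of one without a step beyond the scatter. The weaker number of compound 2 is not shared by compound 3, with a 2.9-fold lower number from compound 2 to compound 3 (0.47 log units; beyond the scatter).

From the compounds shown here alone, whether an amine or a carboxylic acid on this aromatic carbon would fit the same picture stays open, as does the separate share of bromo and fluoro in compound 2. Nothing here gives a measured reason for either step.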